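Removing the Methyl from a Ring Amine Nitrogen

This account rests on a few compounds, and the source may have more. Where it says the series, first, only, none or still open, it means among the compounds named here.

The compounds share a pyridine bearing a saturated nitrogen ring and a further substituent. Compound 1 `COCC[C@H]1C[C@@H]1c1cncc(N2C[C@@H]3C[C@H]2CN3)c1` carries a bridged bicyclic amine, while compound 2 `COCC[C@H]1C[C@@H]1c1cncc(N2CCCNCC2)c1` carries a seven-membered ring amine with a free hydrogen. In an assay on SH-EP1 cells for agonist activity at Neuronal acetylcholine receptor; alpha4/beta2 (Homo sapiens), read by rubidium efflux, with a stated time of 9.5 min (a higher number here means a larger maximal response, a lower number a smaller maximal response), compound 2 gives 81%, and for compound 1 the result is recorded as "not determined" (no result reported). Compound 3 `CN1CCCN(c2cncc(-c3cc(CCO)no3)c2)CC1` combines the methylated seven-membered ring amine with an isoxazole chain; in this assay compound 3 is likewise recorded as "not determined" (no result reported), so there is no number on which it stands, and one further compound is in the same position. Compound 4 `OCCc1cc(-c2cncc(N3CCCNCC3)c2)on1` differs from compound 3 by hydrogen in place of methyl on an amine nitrogen in a ring. Among the compounds with values here, since compound 3 has no number, no step can be sized, and only compound 2 offers a comparable unsubstituted ring amine. On that basis compound 4 is expected to give a maximal response close to that of compound 2, estimated at 80% in this assay, within a range from 55% to 100%. The other substituent on the pyridine of compound 4 is different from that of compound 2, so this expectation is held loosely.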

Compound 4, largest response reached (reported as efficacy), in percent of the reference or control that the assay uses: 58%
Beside the measured number, compound 4's estimate is 22 percentage points above it, and the stated range covers the measured number.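

Within the data shown here, compound 3 has no number in this assay, while compound 4 gives 58%, so no step between compound 3 and compound 4 can be read. The compounds shown leave open how the methyl on the ring amine nitrogen bears on the maximal response. No evidence offered here speaks to this result.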